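Sulfonyl group swap near the clearance limit

The compounds below may be only part of what the source reports. "The series", "measured", "known", "first", "only" and "open" are said of these compounds alone.

The series keeps the core of compound 1 `CCn1c([C@@H](C)NS(=O)(=O)c2cccc(C#N)c2)nc2ccc(C(F)(F)F)cc21` and varies the group on a sulfonyl sulfur. In an ADME assay (liver) for metabolic stability, with Liver microsome (Homo sapiens) as the target, read by LC-MS, using microsomes and NADPH, with a stated time of 5 min, at 37 degrees C (on this read-out higher numbers stand for fast clearance and lower numbers for slow clearance), compound 1 gives > 100 mL.min-1.g-1, which is a limit and not a number. In this assay, for the measured compounds named here, compound 2 `CCn1cc(S(=O)(=O)N[C@H](C)c2nc3ccc(C(F)(F)F)cc3n2CC)cn1` gives 95 mL.min-1.g-1, the only true number so far. Compound 3 `CCCn1ncc(S(=O)(=O)N[C@H](C)c2nc3ccc(C(F)(F)F)cc3n2CC)c1C` gives > 100 mL.min-1.g-1, again a limit and not a number. Compound 3 therefore stands at the limit of > 100 mL.min-1.g-1 in this assay, at which 2 of the 3 values shown sit.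

Compound 4 `CCn1c([C@@H](C)NS(=O)(=O)c2cnc(C)n2C)nc2ccc(C(F)(F)F)cc21` carries 1,2-dimethyl-1H-imidazol-5-yl in place of 5-methyl-1-propyl-1H-pyrazol-4-yl on a sulfonyl sulfur.

Going by the values given here, three measured steps bear on this place. The first is an at least 1.0-fold lower number from compound 1 to compound 2 (0.02 log units; that floor lies within the scatter), the second is an at least 1.0-fold higher number from compound 2 to compound 3 (0.02 log units; that floor lies within the scatter), and the third is a step that the two limits leave unreadable from compound 1 to compound 3. None gives a readable size beyond the scatter, and none involves 1,2-dimethyl-1H-imidazol-5-yl, so the guide is weak. Among the compounds with values here, the one numeric anchor is compound 2 at 95 mL.min-1.g-1, which points to a high number rather than a low one. A lower number of uncertain size is expected, as an at least 1.6-fold lower number from compound 3 to compound 4 (0.22 log units; that floor lies within the scatter). The estimate for compound 4 is 60 mL.min-1.g-1, with an expected range of 25 mL.min-1.g-1 to 130 mL.min-1.g-1.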

Compound 4, intrinsic clearance in microsomes: 58 mL.min-1.g-1
Compound 4: middle estimate off by 1.0-fold (0.01 log units), on the high side, within the range that was stated.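

Compound 4 adds a second true number at this position in this assay, so a step between two numbers can be read: 1,2-dimethyl-1H-imidazol-5-yl in place of 1-ethyl-1H-pyrazol-4-yl on the sulfonyl sulfur gives a 1.6-fold lower number from compound 2 to compound 4 (0.21 log units; within the scatter), and these two heteroaryl groups cannot be told apart on this read-out. Against the two limit compounds only floors can be stated, an at least 1.7-fold lower number from compound 3 to compound 4 (0.23 log units; that floor lies within the scatter) and an at least 1.7-fold lower number from compound 1 to compound 4 (0.23 log units; that floor lies within the scatter), so the true size of either step stays unknown and neither floor shows a change beyond the scatter. The steps that join limits to limits still cannot be read, and the limit remains a common result for this position: the limit of > 100 mL.min-1.g-1 in this assay, at which 2 of the 4 values shown sit.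

The values shown do not separate the effect of the ring type from that of its methyl groups, since no imidazolyl and pyrazolyl group with matching substituents can be compared here. Also open, as far as these compounds go, is whether a group of another kind on the sulfonyl sulfur, such as a piperidin-1-yl ring, a morpholin-4-yl ring or a phenyl ring carrying a carboxylic acid, would move the number beyond the scatter from compound 2.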